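A few compounds are considered here, and "the series" means these few. Any claim that something is new, unique, unknown or untested is made for them only; others in the source may bear on it.

Compound 1 `Fc1ccc2[nH]c(-c3cn(-c4ccccc4)nc3-c3ccccc3)nc2c1` gives 2430 nM in a functional assay on MCF7 cells (Homo sapiens) for antiproliferative activity, read by MTT assay, with a stated time of 48 h; a higher number here means a weaker inhibitor, a lower number a stronger inhibitor. Compound 2 `Clc1ccc2[nH]c(-c3cn(-c4ccccc4)nc3-c3ccccc3)nc2c1` gives 1960 nM in this assay; the structural difference is chloro in place of fluoro on an aromatic carbon, and the step is a 1.2-fold lower number from compound 1 to compound 2 (0.09 log units; within the scatter). Compound 3 `Fc1ccc2[nH]c(-c3cn(-c4ccccc4)nc3-c3ccc(Cl)cc3)nc2c1` gives 2830 nM in this assay; it differs from compound 1 by chloro in place of hydrogen on an aromatic carbon, with a 1.2-fold higher number from compound 1 to compound 3 (0.07 log units; within the scatter). Compound 4 `Clc1ccc(-c2nn(-c3ccccc3)cc2-c2nc3cc(Cl)ccc3[nH]2)cc1` has not yet been measured in this assay. It differs from compound 3 by chloro in place of fluoro on an aromatic carbon, the same change, at the same place, as that from compound 1 to compound 2; the two cores differ by chloro in place of hydrogen on an aromatic carbon. For compound 4 in this assay a step of similar size is expected, a 1.2-fold lower number from compound 3 to compound 4 (0.09 log units; within the scatter), because the earlier instance gave a 1.2-fold lower number from compound 1 to compound 2 (0.09 log units; within the scatter). Compound 4 is therefore estimated at 2300 nM, in a range from 1200 nM to 4500 nM.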

Compound 4, half-maximal inhibitory concentration: 1170 nM
Compound 4: middle estimate off by 2.0-fold (0.29 log units), on the high side, outside the stated range (below it).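

In this assay, chloro in place of fluoro gives a 2.4-fold lower number from compound 3 to compound 4 (0.38 log units; beyond the scatter), a modest step on its own, but it does not differ from the earlier instance of the same change beyond what two such steps allow: the same change on two cores in this assay, a 1.2-fold lower number (0.09 log units; within the scatter) from compound 1 to compound 2 and a 2.4-fold lower number (0.38 log units; beyond the scatter) from compound 3 to compound 4, 2.0-fold (0.29 log units) apart, within the scatter of two such steps. Chloro in place of hydrogen gives a 1.7-fold lower number from compound 2 to compound 4 (0.22 log units; within the scatter), and this step also agrees with its earlier instance: the same change on two cores in this assay, a 1.2-fold higher number (0.07 log units; within the scatter) from compound 1 to compound 3 and a 1.7-fold lower number (0.22 log units; within the scatter) from compound 2 to compound 4, 2.0-fold (0.29 log units) apart, within the scatter of two such steps. Both changes therefore carry between these two cores without a demonstrated dependence on the core, though a single pair of cores for each change cannot show that the steps are equal or that the two changes act independently.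

The compounds shown carry only fluoro, chloro or hydrogen at the two changed places. As far as these compounds go, whether an amine, a methoxy group or a carboxylic acid at either place would shift the number beyond the scatter remains open.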